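The compounds below may be only part of what the source reports. "The series", "measured", "known", "first", "only" and "open" are said of these compounds alone.

Two members of this series have been examined in a functional assay on OVCAR-8 cells (Homo sapiens) for inhibition; on this read-out higher numbers stand for weaker inhibition of growth and lower numbers for stronger inhibition of growth. Compound 1 `COc1cc(/C=C/C(=O)c2cccc(-n3cc(-c4ccccc4)[nH]c3=O)c2)cc(OC)c1OC` gives 1620 nM in this assay. Compound 2 `COc1ccc(-c2cn(-c3cccc(C(=O)/C=C/c4ccc(O)c(OC)c4)c3)c(=O)[nH]2)cc1` gives 4970 nM in this assay, the highest of the two numbers recorded so far; its nearest neighbour is compound 1, whose number is lower by a margin that lies beyond the usual scatter of the measurement. The two compounds differ in more than one place, so their gap is simply what the two values show.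

Compound 3 `COc1ccc(-c2cn(-c3cccc(C(=O)/C=C/c4cc(OC)c(OC)c(OC)c4)c3)c(=O)[nH]2)cc1` has not yet been measured. It differs from compound 2 in one place: 3,4,5-trimethoxyphenyl in place of 4-hydroxy-3-methoxyphenyl on a double-bonded chain carbon bound to a double-bonded chain carbon. In this assay compound 3 is expected to show a step from compound 2 of a 2.3-fold lower number from compound 2 to compound 3 (0.35 log units; beyond the scatter), toward stronger inhibition of growth, since compound 1, which also holds a 3,4,5-trimethoxyphenyl, gives 1620 nM. Compound 3 is therefore estimated at 2200 nM in this assay, with a range from 900 nM to 5500 nM.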

Compound 3, concentration for 50% growth inhibition: 2530 nM
Compound 3: middle estimate off by 1.2-fold (0.06 log units), on the low side; measured number inside the range.
By their numbers in this assay, from the lowest: compounds 1, 3 and 2 (each within the scatter of the next, the first and the last beyond it).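

Moving to 3,4,5-trimethoxyphenyl in place of 4-hydroxy-3-methoxyphenyl on a double-bonded chain carbon bound to a double-bonded chain carbon gives a 2.0-fold lower number from compound 2 to compound 3 (0.29 log units; within the scatter) in this assay and is the first one-place reading at this position: the entering group has no hydrogen-bond donor and 12 heavy atoms against 9, yet the number does not move clear of the scatter. The other one-place change, methoxy in place of hydrogen on an aromatic carbon, gives a 1.6-fold higher number from compound 1 to compound 3 (0.19 log units; within the scatter) in the same read-out, so neither change separates its pair of compounds here. No measurement at hand accounts for either step.

It remains open whether a phenyl bearing a dimethylamino group or a carboxylic acid at the place of the 3,4,5-trimethoxyphenyl would shift the number beyond the scatter, since both groups shown at this place are phenyl rings carrying methoxy. From the compounds shown here alone, the methoxy change can also be read only with 3,4,5-trimethoxyphenyl on the chain, so its size with 4-hydroxy-3-methoxyphenyl there remains unknown.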